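A few compounds are considered here, and "the series" means these few. Any claim that something is new, unique, unknown or untested is made for them only; others in the source may bear on it.

In an assay on HEK293 cells for inhibition of Indoleamine 2,3-dioxygenase 1 (Homo sapiens), tested at 10 uM (a lower number here means less inhibition, a higher number more inhibition at the concentration tested (going by the name of the read-out)), compound 1, with the structure `CCC(=O)N1CCc2cc(CNC(=O)c3ccnn3C)ccc21`, gives 14%. That is the lowest of the three numbers at hand. Compound 2, with the structure `CC(C)CC(=O)N1CCc2cc(CNC(=O)c3cccnc3)ccc21`, gives 86% in this assay, and compound 3, with the structure `CCCC(=O)NCc1ccc2c(c1)CCN2C(=O)CC(C)C`, gives 64%. Among the measured compounds shown here, compound 2 and compound 3 share one core and differ only in the group on the amide carbonyl; that step, a number 22 percentage points lower from compound 2 to compound 3 (beyond the scatter), is the only measured step on that carbonyl carbon.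

Compound 4, with the structure `CCC(=O)N1CCc2cc(CNC(=O)c3cccs3)ccc21`, is not yet measured. Compared with compound 1 it differs in one place: thiophen-2-yl in place of 1-methyl-1H-pyrazol-5-yl on a carbonyl carbon. The measured step from compound 2 to compound 3 concerns the same carbonyl carbon, but it trades an aromatic ring for a chain, whereas here one five-membered aromatic ring replaces another; it therefore bears only loosely on the present change, and compound 1 itself is separated from compound 2 and compound 3 in two places at once. The size of that step suggests that the group on this carbonyl can move the read-out by a modest amount. A modest rise is expected for compound 4, as the step of a number 21 percentage points higher from compound 1 to compound 4 (beyond the scatter). Compound 4 is estimated to give 35% in this assay, within a range from 10% to 65%.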

Compound 4, a percentage reported as inhibition, at one concentration (the size of the read-out at that concentration, not a potency): 89%
The estimate for compound 4 lay 54 percentage points below the measured number; the measured number lies above the stated range.
By their numbers in this assay, from the lowest: compound 1; then compound 3; then compounds 2 and 4 (each within the scatter of the next).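

In this assay, replacing 1-methyl-1H-pyrazol-5-yl with thiophen-2-yl on a carbonyl carbon gives a number 75 percentage points higher from compound 1 to compound 4 (beyond the scatter), with the rest of the molecule unchanged. Among the compounds shown here, this is the first measured exchange of one five-membered aromatic ring for another at this position, and it shows that the choice of ring alone can produce a large change, whereas the only earlier step here, a number 22 percentage points lower from compound 2 to compound 3 (beyond the scatter), was modest and replaced a ring with a chain. The two rings differ in their heavy atoms, hetero atoms and hydrogen-bond acceptors, but no measurement available here explains the rise or shows which of these differences matters.

As far as these compounds go, it remains open whether the high number depends on thiophen-2-yl in particular or would also appear with a close relative such as furan-2-yl, thiophen-3-yl or phenyl, or with an amine on the same carbonyl carbon. Compound 2 and compound 4 differ in two places, at both amide groups, so the compounds shown cannot separate the effects of pyridin-3-yl and thiophen-2-yl from that of the other amide group.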